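The compounds below may be only part of what the source reports. "The series", "measured", "known", "first", "only" and "open" are said of these compounds alone.

Three compounds built on one shared core were measured in an ADME assay on Caco-2 cells (Homo sapiens) for permeability, in the apical to basolateral direction; a higher number here means that the compound crosses the layer faster, a lower number that the compound crosses the layer more slowly. Compound 1 `Cn1cncc1CN1CC(N(CC2CCN(C(=O)C(C)(C)C)CC2)S(=O)(=O)c2ccccn2)Cc2cc(C#N)ccc21` gives 0.5 10^-6 cm/s, and compound 2 `CCC(=O)N1CCC(CN(C2Cc3cc(C#N)ccc3N(Cc3cncn3C)C2)S(=O)(=O)c2ccccn2)CC1` gives 0.5 10^-6 cm/s. Compound 3 `CC(C)S(=O)(=O)N1CCC(CN(C2Cc3cc(C#N)ccc3N(Cc3cncn3C)C2)S(=O)(=O)c2ccccn2)CC1` gives 0.1 10^-6 cm/s, the lowest of the three numbers. The step of no change at the digits printed from compound 1 to compound 2 (within the scatter) leaves the read-out where it was, whereas a 5.0-fold lower number from compound 1 to compound 3 (0.70 log units; beyond the scatter) and a 5.0-fold lower number from compound 2 to compound 3 (0.70 log units; beyond the scatter) both move it down by the same modest amount when an acyl group on the ring nitrogen gives way to a sulfonyl.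

Compound 4 `Cn1cnc(S(=O)(=O)N2CCC(CN(C3Cc4cc(C#N)ccc4N(Cc4cncn4C)C3)S(=O)(=O)c3ccccn3)CC2)c1` keeps that sulfonyl and differs from compound 3 in one place: 1-methyl-1H-imidazol-4-yl in place of isopropyl on a sulfonyl sulfur. Among the compounds with values here, none of the measured steps changes the group on the sulfonyl sulfur, so they bear on compound 4 only in setting its starting point, compound 3 with its 0.1 10^-6 cm/s. Within the data shown here, with no direct precedent, the step is expected to be small, a 1.3-fold lower number from compound 3 to compound 4 (0.10 log units; within the scatter), and to stay within the scatter. Compound 4 is therefore estimated at 0.08 10^-6 cm/s, with a range from 0.03 10^-6 cm/s to 0.25 10^-6 cm/s.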

Compound 4, apparent permeability: 0.1 10^-6 cm/s
The estimate for compound 4 lay 1.3-fold (0.10 log units) below the measured number; measured number inside the range.
By their numbers in this assay, from the lowest: compounds 3 and 4 (each within the scatter of the next); then compounds 1 and 2 (each within the scatter of the next).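

On a sulfonyl sulfur whose other neighbour is a sulfonamide nitrogen in a ring, 1-methyl-1H-imidazol-4-yl in place of isopropyl gives no change at the digits printed from compound 3 to compound 4 (within the scatter) in this assay, so this larger group with its five-membered aromatic ring leaves the read-out where it stood. Against the two acyl compounds, (1-methyl-1H-imidazol-4-yl)sulfonyl gives a 5.0-fold lower number from compound 2 to compound 4 (0.70 log units; beyond the scatter) and a 5.0-fold lower number from compound 1 to compound 4 (0.70 log units; beyond the scatter), so the gap first seen with isopropylsulfonyl now holds for a second sulfonyl group, and none of the four compounds goes against it. Nothing shown here gives a reason for this result.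

As far as these compounds go, whether a sulfonyl carrying an amine, a carboxylic acid or a longer chain on the sulfur would stay at this level remains open. So does the place in this assay of a urea or a carbamate on the same ring nitrogen.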